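Replacing Benzyloxy with Methoxymethoxy on a Shared Core

The compounds below may be only part of what the source reports. "The series", "measured", "known", "first", "only" and "open" are said of these compounds alone.

Measured in a functional assay on J774.A1 cells (Mus musculus) for inhibition, read by immunoassay, with a stated time of 12 h, tested at 30 uM; on this read-out higher numbers stand for more inhibition at the one concentration tested (going by the name of the read-out) and lower numbers for less inhibition:
compound 1 `CCCOc1ccccc1C1CC(=O)c2ccccc2O1` gives 43.6%
compound 2 `CCCCCOc1ccccc1C1CC(=O)c2ccccc2O1` gives 40.1%
compound 3 `O=C1CC(c2ccccc2OCc2ccccc2)Oc2ccccc21` gives 91.5%

Compound 3 stands highest of the three in this assay; compound 1 is its nearest neighbour and compound 2 the furthest, both lower by steps beyond the scatter, while compound 1 and compound 2 lie within the scatter of each other. Compound 4 `COCOc1ccccc1C1CC(=O)c2ccccc2O1` is not yet measured. It differs from compound 3 in this way: methoxy in place of phenyl on a saturated chain carbon bound to an oxygen on an aromatic ring. Going by the values given here, two measured steps bear on it, a number 47.9 percentage points higher from compound 1 to compound 3 (beyond the scatter) and a number 51.4 percentage points higher from compound 2 to compound 3 (beyond the scatter), both large gains when phenyl entered in place of a chain. Removing the phenyl again is expected to reverse that gain, so the step of a number 46.5 percentage points lower from compound 3 to compound 4 (beyond the scatter) is expected. Compound 4 is therefore estimated at 45%, ranging from 25% to 70%.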

Compound 4, a percentage reported as inhibition, at one concentration (the size of the read-out at that concentration, not a potency): 33.3%
The estimate for compound 4 lay 11.7 percentage points above the measured number; measured number inside the range.
By their numbers in this assay, from the lowest: compounds 4, 2 and 1 (each within the scatter of the next, the first and the last beyond it); then compound 3.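

In this assay the change from benzyloxy to methoxymethoxy gives a number 58.2 percentage points lower from compound 3 to compound 4 (beyond the scatter) and shows that a chain carrying an oxygen, like the plain chains, does not reach the number of compound 3. Against those plain chains, methoxy in place of butyl gives a number 6.8 percentage points lower from compound 2 to compound 4 (within the scatter) while methoxy in place of ethyl gives a number 10.3 percentage points lower from compound 1 to compound 4 (beyond the scatter) and only the latter step is beyond the scatter. Nothing measured here explains these steps.

The compounds shown leave open whether another ring on this chain carbon, such as pyridyl or cyclohexyl, would keep the high number of compound 3. They also leave open how an amine at this place would compare with methoxy.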